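Morpholine amide in place of ethyl amide at the sugar carbonyl

A few compounds are considered here, and "the series" means these few. Any claim that something is new, unique, unknown or untested is made for them only; others in the source may bear on it.

Compound 3 `CCNC(=O)[C@H]1O[C@@H](n2cnc3c(NCc4cccc(I)c4)nc(Cl)nc32)[C@H](O)[C@@H]1O` gives 0.891 nM in an assay on CHO cells for displacement of a labelled ligand from adenosine receptor A3 (Homo sapiens); a higher number here means a weaker inhibitor, a lower number a stronger inhibitor. Among the three measured compounds it holds the second highest number: compound 1 `CCNC(=O)[C@H]1O[C@@H](n2cnc3c(NC4CC4)nc(Cl)nc32)[C@H](O)[C@@H]1O` gives 0.676 nM, and the step of a 1.3-fold higher number from compound 1 to compound 3 (0.12 log units; within the scatter) is within the scatter; compound 2 `CNC(=O)[C@H]1O[C@@H](n2cnc3c(NC4CCCC4)nc(Cl)nc32)[C@H](O)[C@@H]1O` gives 4.27 nM, the furthest value, beyond the scatter from compound 3. Compound 4 `O=C([C@H]1O[C@@H](n2cnc3c(NCc4cccc(I)c4)nc(Cl)nc32)[C@H](O)[C@@H]1O)N1CCOCC1` differs from compound 3 by morpholin-4-yl in place of ethylamino on a carbonyl carbon. Going by the values given here, no measured step alters this carbonyl substituent alone; compounds 1 and 2 differ there and elsewhere, so their values show nothing separable. Among the compounds with values here, the only step, from compound 1 to compound 3, concerns a different position and is within the scatter. Within the data shown here, the expectation for compound 4 therefore rests on no direct precedent and is set wide, as a step of a 34-fold higher number from compound 3 to compound 4 (1.53 log units; beyond the scatter). Compound 4 is expected at 30 nM, with a range of 3 nM to 300 nM.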

Compound 4, inhibition constant: 513 nM
Compound 4: middle estimate off by 17-fold (1.23 log units), on the low side; measured number outside the range, above it.
By their numbers in this assay, from the lowest: compounds 1 and 3 (each within the scatter of the next); then compound 2; then compound 4.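

Morpholin-4-yl in place of ethylamino on the carbonyl carbon gives a 580-fold higher number from compound 3 to compound 4 (2.76 log units; beyond the scatter), so this position responds strongly to change, unlike the earlier step at the other position, a 1.3-fold higher number from compound 1 to compound 3 (0.12 log units; within the scatter). The change removes the amide hydrogen and adds a six-membered ring at once, and this single step cannot separate the two. Nothing measured here accounts for the size of the step.

Open, going by these compounds, is whether dimethylamino, with no amide hydrogen and no ring, behaves like morpholin-4-yl. Also open, on these data alone, is whether piperidin-1-yl or a longer chain on the amide nitrogen stays close to compound 3.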